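A cyclopropyl exchanged for an aryl group on a weak core

The source may hold more compounds than are shown below. What is called first, only, known or untested is meant among the compounds shown, and "the series" means these compounds.

Compound 1, with the structure `O=C1COc2ccc(-c3cccc(NS(=O)(=O)c4ccc(F)cc4)c3)cc2N1C1CC1`, was tested in a functional assay on MCF7 cells (Homo sapiens) for antiproliferative activity, read by MTT assay, with a stated time of 72 h; on this read-out lower numbers stand for stronger inhibition and higher numbers for weaker inhibition. Compound 1 gives > 40000 nM, which is a limit of the assay rather than a number. The same limit holds for compound 2, `O=C1COc2ccc(-c3cnc(Cl)c(NS(=O)(=O)c4ccc(F)cc4)c3)cc2N1c1ccccc1`, which gives > 40000 nM, again only a limit. Compound 3, `O=C1COc2ccc(-c3cnc(Cl)c(NS(=O)(=O)c4ccc(F)cc4)c3)cc2N1c1ccc(F)cc1`, gives 32600 nM. Going by the values given here, the one measured step, an at least 1.2-fold lower number from compound 2 to compound 3 (0.08 log units; that floor lies within the scatter), shows that the shared core with an aryl group on the amide-type nitrogen stays close to the limit, a point also made by the limit of > 40000 nM in this assay, at which 2 of the 3 values shown sit.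

Compound 4, `COc1cccc(N2C(=O)COc3ccc(-c4cccc(NS(=O)(=O)c5ccc(F)cc5)c4)cc32)c1`, differs from compound 1 in one place: 3-methoxyphenyl in place of cyclopropyl on an amide-type nitrogen in a ring. Compounds 2 and 3 carry aryl groups at the same position on a different core and remain weak, so no move beyond the scatter is expected from compound 1 to compound 4, and a reading at the limit is quite possible. Compound 4 is therefore estimated at 40000 nM, between 15000 nM and 100000 nM, which is expected to amount to a number no higher from compound 1 to compound 4 (the limit leaves the size open).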

Compound 4, half-maximal inhibitory concentration: > 40000 nM
Compound 4: a limit, no number; the forecaster's own chance of this, stated with the estimate: 55%; the middle value sits exactly at the limit.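

In this assay compound 4 gives > 40000 nM, which is a limit and not a number. Compound 1 also stands at a limit, so no step can be read between compound 1 and compound 4. Left open is whether 3-methoxyphenyl or cyclopropyl gives the lower number on the core of compound 1: the limit of > 40000 nM in this assay, at which 3 of the 4 values shown sit.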